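Swapping a thiophene ring for a bromophenyl on the ketone

This account rests on a few compounds, and the source may have more. Where it says the series, first, only, none or still open, it means among the compounds named here.

Three measured compounds share one core and differ only in the group attached to a carbonyl carbon. Compound 1 `COc1cc(-c2nnc3n2NC(c2ccco2)C(C(=O)c2ccc(Br)cc2)S3)cc(OC)c1OC` carries a 4-bromophenyl there, and in a functional assay on A549 cells (Homo sapiens) for cytotoxicity, read by MTT assay, with a stated time of 48 h (on this read-out lower numbers stand for stronger inhibition and higher numbers for weaker inhibition), compound 1 gives 42100 nM. Compound 2 `COc1cc(-c2nnc3n2NC(c2ccco2)C(C(=O)c2cccs2)S3)cc(OC)c1OC` carries a thiophen-2-yl, and in this assay compound 2 gives 78700 nM. Compound 3 `COc1cc(-c2nnc3n2NC(c2ccco2)C(C(=O)c2cccc4ccccc24)S3)cc(OC)c1OC` carries a naphthalen-1-yl. For compound 3 this assay reports only a limit, > 100000 nM, and no number. Compound 2 thus has the highest of the two plain numbers, yet the gap to compound 1 is small, as described below.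

Compound 4 `COc1cc(-c2nnc3n2NC(c2ccco2)C(C(=O)c2cccc(Br)c2)S3)cc(OC)c1OC` keeps the core of compound 2 and alters one group: 3-bromophenyl in place of thiophen-2-yl on a carbonyl carbon. The step that bears most on this change is the one from 4-bromophenyl to thiophen-2-yl: a 1.9-fold higher number from compound 1 to compound 2 (0.27 log units; within the scatter), a shift that stays within the scatter. The move toward a larger carbon-only ring, an at least 1.2-fold higher number from compound 2 to compound 3 (0.10 log units; that floor lies within the scatter), only set a floor. A bromophenyl thus sat near the thiophene in this assay, so a small or no step is expected; compound 4 is expected at 50000 nM, between 20000 nM and 150000 nM, meaning a step of a 1.6-fold lower number from compound 2 to compound 4 (0.20 log units; within the scatter).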

Compound 4, half-maximal inhibitory concentration: 36900 nM
For compound 4 the middle estimate is 1.4-fold (0.13 log units) above the measured one, and the stated range covers the measured number.
By their numbers in this assay, from the lowest: compounds 4, 1 and 2 (each within the scatter of the next, the first and the last beyond it). At a limit, above all of these: compound 3.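

In this assay, the 3-bromophenyl on the carbonyl carbon gives the first step away from the thiophen-2-yl that clears the usual scatter (a 2.1-fold lower number from compound 2 to compound 4 (0.33 log units; beyond the scatter)). The 3-bromophenyl and the 4-bromophenyl, by contrast, cannot be told apart here (a 1.1-fold lower number from compound 1 to compound 4 (0.06 log units; within the scatter)), so these two placings of the bromine give the same reading within the scatter. Against the naphthalen-1-yl the 3-bromophenyl also stands clear (an at least 2.7-fold lower number from compound 3 to compound 4 (0.43 log units; beyond the scatter)), but that step is only a floor, as compound 3 has a limit and not a number: the limit of > 100000 nM in this assay, at which 1 of the 4 values shown sits.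

From the compounds shown here alone, what a plain phenyl or a 3-methoxyphenyl would give on this carbonyl carbon remains open, so the effect of the bromine cannot yet be separated from that of the six-membered carbon ring carrying it. Going by these compounds, all these readings also come from one assay on one cell line, so it stays open whether the gap between the 3-bromophenyl and the thiophen-2-yl would hold on other cells.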